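Ethyl Ester Against Free Acid Across Two Cores

The source may report more compounds than this note shows. Statements on the series, on what has been measured and on what is new or still open speak of the compounds shown alone.

Compound 1 `C=CC(=O)Nc1ccc(Cn2nc(-c3ccc(Oc4ccccc4)cc3)cc2C(=O)O)cc1` carries a free acid. In a functional assay on Rec1 cells (Homo sapiens) for inhibition, read by luminescence and CellTiter-Glo, with a stated time of 72 h (on this read-out lower numbers stand for stronger inhibition and higher numbers for weaker inhibition), compound 1 gives > 60000 nM, which is a limit of the assay rather than a number (the limit of > 60000 nM in this assay, at which 1 of the 3 values shown sits). Compound 2 `C=CC(=O)Nc1ccc(Cn2nc(-c3ccc(Oc4ccccc4)cc3)cc2C(=O)OCC)cc1` is its ethyl ester, and in this assay compound 2 gives 2800 nM. The change from compound 1 to compound 2 is ethyl in place of hydrogen on an oxygen next to a carbonyl group, and it produces an at least 21-fold lower number from compound 1 to compound 2 (1.33 log units; beyond the scatter).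

Compound 3 `C=CC(=O)N1CCCC(n2nc(-c3ccc(Oc4ccccc4)cc3)cc2C(=O)O)C1` carries the same free acid on a different core; the difference between the cores of compound 1 and compound 3 is not broken down here. In this assay, going by the values given here, compound 3 gives 50000 nM, a weaker result than compound 2 and the weakest of the plain numbers measured so far.

Compound 4 `C=CC(=O)N1CCCC(n2nc(-c3ccc(Oc4ccccc4)cc3)cc2C(=O)OCC)C1` has not yet been measured. Among the compounds with values here, it differs from compound 3 by ethyl in place of hydrogen on an oxygen next to a carbonyl group, the same change at the same place as the one between compound 1 and compound 2. Given that the step from compound 1 to compound 2 produced an at least 21-fold lower number from compound 1 to compound 2 (1.33 log units; beyond the scatter), the ester of compound 3 is expected to show a gain of a comparable size, so the step from compound 3 to compound 4 in this assay is estimated at a 20-fold lower number from compound 3 to compound 4 (1.30 log units; beyond the scatter). On that basis compound 4 is expected to give about 2500 nM, most likely between 500 nM and 15000 nM.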

Compound 4, half-maximal inhibitory concentration: 13800 nM
The estimate for compound 4 lay 5.5-fold (0.74 log units) below the measured number; measured number inside the range.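

On the core of compound 3, ethyl in place of hydrogen on an oxygen next to a carbonyl group again strengthens the result in this assay, with a 3.6-fold lower number from compound 3 to compound 4 (0.56 log units; beyond the scatter), so the direction of the change carries over from the core of compound 1 to this second core. The size of the step does not carry over, and the gain on the second core is clearly the smaller of the two: the same change on two cores in this assay, an at least 21-fold lower number (1.33 log units; beyond the scatter) from compound 1 to compound 2 and a 3.6-fold lower number (0.56 log units; beyond the scatter) from compound 3 to compound 4, at least 5.9-fold (0.77 log units) apart, beyond the scatter of two such steps

The earlier step starts from compound 1, whose result is a limit of the assay and not a number, so its full size stays unknown, and with only one pair on each core the data do not show why the two steps differ or how the change would behave on any further core: the limit of > 60000 nM in this assay, at which 1 of the 4 values shown sits.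

The compounds shown hold only the carboxylic acid and its ethyl ester, which leaves open whether a methyl ester, a longer chain on the same oxygen or a primary amide in place of the acid would follow the same course on either core. They also leave open whether the difference in step size would persist in any read-out other than this assay.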